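Fluorophenyl rearrangement in a diarylidene diketopiperazine pair

A few compounds are considered here, and "the series" means these few. Any claim that something is new, unique, unknown or untested is made for them only; others in the source may bear on it.

Two measured compounds set the frame. Among the measured compounds shown here, compound 1 `C=CCn1c(=O)/c(=C\c2cccc(F)c2)[nH]c(=O)/c1=C\c1ccccc1OC` gives 8890 nM in a functional assay on HL-60 cells (Homo sapiens) for cytotoxicity, read by CCK-8 assay, with a stated time of 72 h (a lower number here means a stronger inhibitor, a higher number a weaker inhibitor), the highest of the two numbers; compound 2 `COc1ccccc1/C=c1/[nH]c(=O)/c(=C\c2nc[nH]c2C(C)(C)C)[nH]c1=O` gives 70 nM in this assay, and these two share no single-point step, so only their two values are compared. Compound 3 `C=CCn1c(=O)/c(=C\c2ccccc2F)[nH]c(=O)/c1=C\c1ccccc1OC` differs from compound 1 by 2-fluorophenyl in place of 3-fluorophenyl on a double-bonded chain carbon bound to an aromatic carbon. For the measured compounds named here, no measured pair shows what this change does, so the step from compound 1 to compound 3 is expected to stay within the scatter, with no set direction. Compound 3 is therefore expected to give about 7500 nM in this assay, between 2500 nM and 22000 nM. The expected step of a 1.2-fold lower number from compound 1 to compound 3 (0.07 log units; within the scatter) reflects that view.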

Compound 3, half-maximal inhibitory concentration: 18500 nM
The estimate for compound 3 lay 2.5-fold (0.39 log units) below the measured number, and the stated range covers the measured number.
By their numbers in this assay, from the lowest: compound 2; then compound 1; then compound 3.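

Moving the fluorine, with the atom count unchanged, is not neutral in this assay: 2-fluorophenyl in place of 3-fluorophenyl on a double-bonded chain carbon bound to an aromatic carbon gives a 2.1-fold higher number from compound 1 to compound 3 (0.32 log units; beyond the scatter) as a modest change. Among the compounds shown here, this is the first sign that the series responds to where fluorine sits on this phenyl ring, which compound 1 and compound 2 could not show. Nothing at hand accounts for the step. Still open, as far as these compounds go, is how a nitrile or an amine in place of fluorine would read on this ring, and whether the step holds on a different core.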